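The compounds below may be only part of what the source reports. "The series", "measured", "known", "first", "only" and "open" are said of these compounds alone.

Working notes on the series: in a functional assay on HL-60 cells (Homo sapiens) for cytotoxicity, read by WST assay, with a stated time of 48 h (a higher number here means that more compound is needed for the effect, a lower number that less compound is needed), only two compounds have numbers so far. Compound 1 (`O=C1OC[C@H](Cc2ccccc2)[C@H]1Cc1ccc(Cl)cc1Cl`) gives 19000 nM and compound 2 (`O=C1OC[C@H](Cc2ccccc2O)[C@H]1Cc1ccc(Cl)c(Cl)c1`) gives 33000 nM in the same read-out. These two values lie within the usual scatter of each other, so compound 2 stands level with compound 1 on the present data.

Compound 3 (`Cc1ccccc1C[C@H]1COC(=O)[C@@H]1Cc1ccc(Cl)c(Cl)c1`) is the next entry and comes from compound 2 by one change, methyl in place of hydroxy on an aromatic carbon, ortho to a large group: methyl in place of hydroxy on an aromatic carbon. The same difference can be read as 2-hydroxyphenyl to 2-methylphenyl.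

For the measured compounds named here, no measured pair isolates this change, so the expectation for this assay rests on how close the two known values are. No step beyond the scatter is expected, and the estimated step is a 1.3-fold lower number from compound 2 to compound 3 (0.12 log units; within the scatter) in size. For compound 3 the estimated value is 25000 nM with 10000 nM to 60000 nM as the expected range.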

Compound 3, half-maximal effective concentration: 22000 nM
The estimate for compound 3 lay 1.1-fold (0.06 log units) above the measured number, within the range that was stated.
By their numbers in this assay, from the lowest: compounds 1, 3 and 2 (each within the scatter of the next).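

In this assay, the first pair differing in one place gives a 1.5-fold lower number from compound 2 to compound 3 (0.18 log units; within the scatter) for methyl in place of hydroxy on an aromatic carbon, ortho to a large group. Compounds 1 and 2 differ in more than one place and could not isolate this position; the new pair shows that the hydroxy, with its 1 hydrogen-bond donor and 1 hydrogen-bond acceptor, can give way to a methyl with 0 of each without a step beyond the scatter in this read-out. No measurement available here bears on why these two groups read alike.

On these data alone, this is one change at one position in one assay, and with only hydroxy and methyl there, it remains open whether an amine, a carboxylic acid, a methoxy group or a longer chain at the same place would give a step beyond the scatter. As far as these compounds go, it also remains open whether 2-hydroxyphenyl to 2-methylphenyl reads the same when the chlorines sit as they do in compound 1, or when the rest of the core is altered.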